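A few compounds are considered here, and "the series" means these few. Any claim that something is new, unique, unknown or untested is made for them only; others in the source may bear on it.

Measured compounds:
- Compound 1 `CCCCCCCOc1cccc(C[C@H]2C(=O)OC[C@@H]2Cc2ccccc2)c1`: 81000 nM
- Compound 2 `CCCCCCCOc1ccc(C[C@H]2C(=O)OC[C@@H]2Cc2ccccc2)cc1`: > 100000 nM (a limit of the assay)
- Compound 3 `COc1cccc(C[C@H]2COC(=O)[C@@H]2Cc2ccc(Cl)c(Cl)c2)c1`: 34000 nM

In a functional assay on HL-60 cells (Homo sapiens) for cytotoxicity, read by WST assay, with a stated time of 48 h (a higher number here means that more compound is needed for the effect, a lower number that less compound is needed), compound 3 gives 34000 nM, the lowest of the two true numbers in this small set. Its gap to compound 1, at 81000 nM, lies beyond the scatter. Compound 2 gives > 100000 nM, which is a limit of the assay and not a number.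

The next compound to be tested is compound 4 `O=C1OC[C@H](Cc2ccc(F)cc2)[C@H]1Cc1ccc(Cl)c(Cl)c1`, which carries 4-fluorophenyl in place of 3-methoxyphenyl on a saturated chain carbon bound to a saturated ring carbon. The rest of the structure of compound 3 stays as it is.

Among the measured compounds shown here, no pair of measured compounds differs in one place only, so the data give no direct measure of what such an exchange does in this assay. The expectation therefore starts from compound 3 at 34000 nM, the closest measured relative, and no shift beyond the scatter is expected in either direction. The estimated change is a 1.1-fold higher number from compound 3 to compound 4 (0.02 log units; within the scatter), which is expected to be small. For compound 4 the estimated value is 36000 nM, with an expected range from 12000 nM to 90000 nM.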

Compound 4, half-maximal effective concentration: 14000 nM
Compound 4: middle estimate off by 2.6-fold (0.41 log units), on the high side; low and high end bracket the measured number.
By their numbers in this assay, from the lowest: compound 4; then compound 3; then compound 1. At a limit, above all of these: compound 2.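

In this assay, putting 4-fluorophenyl in place of 3-methoxyphenyl on a saturated chain carbon bound to a saturated ring carbon gives a 2.4-fold lower number from compound 3 to compound 4 (0.39 log units; beyond the scatter). Among the compounds shown here, this is the first change in the set that can be read in one place alone, with the rest of the structure of compound 3 left as it is, and the earlier compounds gave no such reading. It shows that the aromatic group at this position has a modest but real bearing on the number, since the step lies beyond the usual scatter, while nothing measured here accounts for that step.

The exchange alters both the substituent on the phenyl ring and the number in the group's name, so this single step cannot tell whether the fluorine, the loss of the methoxy group or the different placing matters, and 3-fluorophenyl and 4-methoxyphenyl would be needed to separate them. On these data alone, it also remains open how this position would respond to a group of another kind, such as an aminophenyl or a carboxylic acid on the phenyl ring, or to a longer chain.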